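A Larger Aromatic Arm on a Cytotoxicity Benchmark

This account rests on a few compounds, and the source may have more. Where it says the series, first, only, none or still open, it means among the compounds named here.

Measured compounds:
compound 1, `CN1Cc2ccc(OCc3ccc(-c4ccccc4)cc3)cc2[C@@H](O)C1`, 23000 nM
compound 2, `CN1Cc2ccc(OCCCN3CCNCC3)cc2[C@@H](O)C1`, > 100000 nM

Among the compounds with values here, in an ADME assay on Vero cells (Chlorocebus sabaeus) for cytotoxicity, read by sulforhodamine B assay, with a stated time of 72 h (a higher number here means a weaker inhibitor, a lower number a stronger inhibitor), compound 1 gives 23000 nM, and this is the only real number in the set. Compound 2 reaches only a limit in this assay, > 100000 nM, so no number exists for it. The other entry is thus (the limit of > 100000 nM in this assay, at which 1 of the 2 values shown sits), which belongs to compound 2 alone. Within the data shown here, with no pair of measured compounds differing in one place, no measured step is available to lean on.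

Compound 3, `CN1Cc2ccc(OCc3ccc(-c4ccc5ccccc5c4)cc3)cc2[C@@H](O)C1`, differs from compound 1 in one spot: naphthalen-2-yl in place of phenyl on an aromatic carbon. For this change in this assay the expectation is a small step toward a lower number, of a size barely beyond the usual scatter, if beyond it at all. Compound 3 is therefore expected at 12000 nM, with a range from 4000 nM to 40000 nM, the expected step being a 1.9-fold lower number from compound 1 to compound 3 (0.28 log units; within the scatter).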

Compound 3, half-maximal inhibitory concentration: 310 nM
The estimate for compound 3 lay 39-fold (1.59 log units) above the measured number, and the stated range ends above it.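

In this assay, putting naphthalen-2-yl in place of phenyl gives a 74-fold lower number from compound 1 to compound 3 (1.87 log units; beyond the scatter) and shows that this position is far from indifferent to the group it carries. A lower number here means that less compound is needed to harm the cells, so a modest-looking change in the aromatic arm can make a compound much more toxic to them. Neither group has hydrogen-bond donors, hydrogen-bond acceptors or a net charge, so this step comes from a swap between two groups made of aromatic carbon alone.

Still open, on these data alone, is how a different group at this spot, such as an amine, a carboxylic acid or a longer chain, would compare. Nothing measured here explains why the swap has so large an effect.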